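The source may report more compounds than this note shows. Statements on the series, on what has been measured and on what is new or still open speak of the compounds shown alone.

Of the compounds shown here, three of a shared core have been measured in a functional assay for inhibition, with Homo sapiens as the target; on this read-out higher numbers stand for weaker inhibition and lower numbers for stronger inhibition. Compound 1 `Fc1cccc(Nc2nccc(-c3ccccn3)n2)c1` gives 1000 nM in this assay, the lowest of the three numbers. Compound 3 `COc1cccc(Nc2nccc(-c3cc4ccccc4o3)n2)c1` gives 2800 nM in this assay, a gap from compound 1 that lies beyond the usual scatter, and compound 2 `CN(C)c1ccccc1Nc1nccc(-c2ccncc2)n1` gives 36200 nM in this assay, the furthest of the three from compound 1 and likewise well beyond the scatter.

Compound 4 `CC(=O)Nc1cccc(Nc2nccc(-c3ccccn3)n2)c1` has not yet been measured in this assay. It differs from compound 1 in one place: acetamido in place of fluoro on an aromatic carbon. Among the compounds with values here, no measured pair in this set shows a step of this kind, so there is no directly comparable change to lean on. Within the data shown here, the new group is larger than the fluoro it replaces and brings one hydrogen-bond donor and one hydrogen-bond acceptor, but nothing among the measured compounds shows how this assay responds to such an exchange at that position. The expectation for compound 4 is therefore a step of a 1.5-fold higher number from compound 1 to compound 4 (0.18 log units; within the scatter) from compound 1, close to none beyond the scatter, with a wide range in both directions. Compound 4 is expected to give about 1500 nM in this assay, within a range from 400 nM to 6000 nM.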

Compound 4, half-maximal inhibitory concentration: 300 nM
Estimate against measurement, compound 4: 5.0-fold (0.70 log units) above, outside the stated range (below it).
By their numbers in this assay, from the lowest: compound 4; then compound 1; then compound 3; then compound 2.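

In this assay, acetamido in place of fluoro on an aromatic carbon, meta to a large group, gives a 3.3-fold lower number from compound 1 to compound 4 (0.52 log units; beyond the scatter) and so stronger inhibition, a modest step. Within the data shown here, this is the only step in the set that can be read at one place, and it shows that this position takes the larger acetamido group with a gain rather than a loss. Nothing given here explains why the number falls.

From the compounds shown here alone, whether the gain depends on the amide hydrogen, the carbonyl or the larger group as a whole stays open, and an amine, a carboxylic acid or a longer acyl chain at this place would be needed to tell these apart. Going by these compounds, it also stays open whether the same exchange would lower the number on the core of compound 3.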